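This account rests on a few compounds, and the source may have more. Where it says the series, first, only, none or still open, it means among the compounds named here.

In a functional assay on B16-F10 cells (Mus musculus) for antiproliferative activity, read by MTT assay, with a stated time of 48 h (a higher number here means a weaker inhibitor, a lower number a stronger inhibitor), three compounds have been measured:

Compound 1 `COc1ccc(-c2nn(-c3ccccc3)cc2CNc2ccc(Br)cc2)cc1`: 8060 nM
Compound 2 `Cc1ccc(NCc2cn(-c3ccccc3)nc2-c2ccc(C)cc2)cc1`: 7380 nM
Compound 3 `Cc1ccc(-c2nn(-c3ccccc3)cc2CNc2ccc(F)cc2)cc1`: 5670 nM

Compound 3, at 5670 nM, stands within the scatter of both other compounds, so the three values form one level group. The next compound to be tested is compound 4 `Cc1ccc(-c2nn(-c3ccccc3)cc2CNc2ccc(Br)cc2)cc1`. It departs from compound 3 by a single exchange, bromo in place of fluoro on an aromatic carbon, para to a large group, which turns the 4-fluorophenyl into a 4-bromophenyl.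

Among the measured compounds shown here, one measured step touches the same place, a 1.3-fold lower number from compound 2 to compound 3 (0.11 log units; within the scatter), with fluoro in place of methyl on an aromatic carbon. That step stays within the scatter. Compound 1 already carries the (4-bromophenyl)amino group and gives 8060 nM, but it differs from compound 4 elsewhere, so it offers only a rough guide. Neither observation points to a sizeable shift, and no direction can be drawn from them, so no step beyond the scatter is expected in this assay. The expected step is small, a 1.1-fold higher number from compound 3 to compound 4 (0.06 log units; within the scatter). For compound 4 the estimated value is 6500 nM, with an expected range from 3500 nM to 12000 nM.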

Compound 4, half-maximal inhibitory concentration: 6760 nM
Compound 4: middle estimate off by 1.0-fold (0.02 log units), on the low side; low and high end bracket the measured number.
By their numbers in this assay, from the lowest: compounds 3, 4, 2 and 1 (each within the scatter of the next).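

In this assay, the exchange of fluoro for bromo on this aromatic carbon gives a 1.2-fold higher number from compound 3 to compound 4 (0.08 log units; within the scatter), so the two halogens on this phenyl ring cannot be told apart in this read-out. Methyl at the same place adds nothing to separate them, with bromo in place of methyl giving a 1.1-fold lower number from compound 2 to compound 4 (0.04 log units; within the scatter), so methyl, fluoro and bromo now all stand at one level within the scatter. Among the compounds shown here, the new compound also gives the first comparison at the other aryl group with the (4-bromophenyl)amino group held fixed, and methyl in place of methoxy there gives a 1.2-fold lower number from compound 1 to compound 4 (0.08 log units; within the scatter), which also stays within the scatter. No measurement offered here accounts for these results.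

The compounds shown leave open whether a different kind of group at this position, such as an amine, a carboxylic acid or a nitrile, would give a step beyond the scatter. With all four numbers at a single level, they also leave open which part of the shared core, if any, governs the number in this assay.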